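The source may report more compounds than this note shows. Statements on the series, on what has been measured and on what is new or still open speak of the compounds shown alone.

Compound 1 `COc1ccc(C#Cc2ccc(C(=O)N3CCC[C@@H](CO)C3)cc2)c(F)c1`, in a functional assay on TREX cells for negative allosteric modulation of metabotropic glutamate receptor 3 (Rattus norvegicus), read by calcium flux, with a stated time of 2.5 min (on this read-out higher numbers stand for weaker inhibition and lower numbers for stronger inhibition), compound 1 gives > 10000 nM
Compound 2 `COc1ccc(C#Cc2ccc(C(=O)N3CCCC(C)(O)C3)cc2)cc1`, in this assay compound 2 gives 711 nM; 1100 nM (2 entries)
Compound 3 `COc1ccc(C#Cc2ccc(C(=O)N3CC[C@@H](O)C3)cc2)cc1`, in this assay compound 3 gives 10200 nM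

The value given for compound 1 in this assay is a limit, not a number. Compound 1 therefore stands at the weak end of the three results, a position described by the limit of > 10000 nM in this assay, at which 1 of the 3 values shown sits. Going by the values given here, compound 2 is the only member of the set with a clearly measured, stronger result, recorded as several entries, (the several entries of compound 2 in this assay, 711 nM; 1100 nM (2 entries)), while compound 3 sits close to the limit region.

Compound 4 `COc1ccc(C#Cc2ccc(C(=O)N3CCC[C@@H](CO)C3)cc2)cc1F` has the same atoms as compound 1, joined differently: 3-fluoro-4-methoxyphenyl in place of 2-fluoro-4-methoxyphenyl on a triple-bonded carbon. Among the compounds with values here, no pair of measured compounds differs in just this one place, so the size of such a step cannot be read from the data. The author expects the step from compound 1 to compound 4 in this assay to be a modest gain, an at least 2.0-fold lower number from compound 1 to compound 4 (0.30 log units; that floor lies within the scatter), not far beyond the usual scatter, since compound 1 is known only by its limit. For compound 4 the expected value in this assay is 5000 nM, estimated to lie between 1500 nM and 20000 nM.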

Compound 4, half-maximal inhibitory concentration: > 10000 nM
Compound 4: only a limit was reported (the forecaster's own chance of this, stated with the estimate: 40%); at least 2.0-fold (0.30 log units) between middle value and limit.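

In this assay, compound 1 and compound 4 are each known only by a limit, and no step can be read from compound 1 to compound 4. The compounds shown leave open whether 3-fluoro-4-methoxyphenyl in place of 2-fluoro-4-methoxyphenyl changes inhibition at all, and by how much.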